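The compounds below may be only part of what the source reports. "The series", "measured", "known", "first", "only" and "open" are said of these compounds alone.

Measured compounds:
- compound 1 `Nc1ccc2cccc(OCC3CCOC3)c2n1`; in an assay on cells with melanin-concentrating hormone receptor 1 (Homo sapiens) as the target, read by radioligand binding (a higher number here means a weaker inhibitor, a lower number a stronger inhibitor), compound 1 gives 115 nM
- compound 3 `CNc1ccc2cccc(OC(C)CC(C)(C)C)c2n1`; in this assay compound 3 gives 310 nM
- compound 2 `CC(CC(C)(C)C)Oc1cccc2ccc(N3CCCC3)nc12`; in this assay compound 2 reports only a limit, > 2000 nM

Compound 1 holds the lowest of the two numbers shown; the nearest, compound 3, sits a step beyond the scatter above it. The value of compound 2 is a limit of the assay and not a number, so the series has one limit among three values (the limit of > 2000 nM in this assay, at which 1 of the 3 values shown sits).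

Among the measured compounds shown here, the only measured step concerns the amine substituent: an at least 6.4-fold lower number from compound 2 to compound 3 (0.80 log units; beyond the scatter). For the measured compounds named here, it does not touch the ether side chain, so no measured step bears directly on the change now considered.

Compound 4 `Nc1ccc2cccc(OCC3CC3)c2n1` differs from compound 1 in the ether side chain: cyclopropyl in place of oxolan-3-yl on a saturated chain carbon bound to an oxygen on an aromatic ring. Going by the values given here, with no measured step on this position, the expectation rests on compound 1 alone, so a step in this assay from compound 1 to compound 4 is expected to stay within the scatter, with no direction preferred: a 1.3-fold higher number from compound 1 to compound 4 (0.12 log units; within the scatter). Compound 4 is therefore estimated at 150 nM in this assay, with a range from 50 nM to 500 nM.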

Compound 4, half-maximal inhibitory concentration: > 2000 nM
Compound 4 gave a limit, no number; the forecaster's own chance of this, stated with the estimate: 5%; middle value at least 13-fold (1.12 log units) away from the limit.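

The ether side chain is not a silent position in this assay: with the amino group and the core of compound 1 unchanged, cyclopropyl in place of oxolan-3-yl gives an at least 17-fold higher number from compound 1 to compound 4 (1.24 log units; beyond the scatter). Among the compounds shown here, the one step measured earlier, an at least 6.4-fold lower number from compound 2 to compound 3 (0.80 log units; beyond the scatter), concerned only the amine substituent, so this is the first sign that the number also depends on the group carried on a saturated chain carbon bound to an oxygen on an aromatic ring. Compound 4 reports > 2000 nM, which is a limit of the assay and not a number, so the step gives only a minimum size: the limit of > 2000 nM in this assay, at which 2 of the 4 values shown sit.

The change replaces a five-membered ring holding one oxygen with a three-membered ring of carbon only, so the compounds shown do not separate the loss of the ring oxygen from the change in ring size; cyclopentyl or oxetan-3-yl in the same place would pull these two apart. On these data alone, whether the same change carries the same weight with methylamino in place of the amino group also remains open.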